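The source may hold more compounds than are shown below. What is called first, only, known or untested is meant among the compounds shown, and "the series" means these compounds.

Compound 1 `CCC(=O)N(C)c1ccc2[nH]c(-c3n[nH]c4ccccc34)cc2n1` gives 15700 nM in a functional assay on A549 cells (Homo sapiens) for antiproliferative activity, read by MTT assay, with a stated time of 72 h; on this read-out higher numbers stand for weaker inhibition and lower numbers for stronger inhibition.
Compound 2 `CN(C(=O)C(C)(C)C)c1ccc2[nH]c(-c3n[nH]c4ccccc34)cc2n1` gives 24400 nM in this assay.
Compound 3 `CN(C(=O)c1ccc(F)cc1)c1ccc2[nH]c(-c3n[nH]c4ccccc34)cc2n1` gives 9650 nM in this assay.

All three share one core and differ only in the group attached to the carbonyl carbon of the amide. Compound 3 stands at the low end of the three numbers: the step of a 1.6-fold lower number from compound 1 to compound 3 (0.21 log units; within the scatter) is within the scatter, so compound 1 and compound 3 cannot be told apart, while the step of a 2.5-fold lower number from compound 2 to compound 3 (0.40 log units; beyond the scatter) is a real but modest difference. Compound 4 `CN(C(=O)c1ccco1)c1ccc2[nH]c(-c3n[nH]c4ccccc34)cc2n1` differs from compound 3 in one place: furan-2-yl in place of 4-fluorophenyl on a carbonyl carbon. Going by the values given here, no measured step swaps one ring for another, so the only guide is that changing the group on the carbonyl carbon has so far moved this number little, as a 1.6-fold lower number from compound 1 to compound 3 (0.21 log units; within the scatter) and a 2.5-fold lower number from compound 2 to compound 3 (0.40 log units; beyond the scatter) show. A small step, if any beyond the scatter, is therefore expected in this assay, with a slight lean toward a higher number. For compound 4 the expected value is 12000 nM, within a range from 5000 nM to 30000 nM. This estimate corresponds to an expected step of a 1.2-fold higher number from compound 3 to compound 4 (0.09 log units; within the scatter).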

Compound 4, half-maximal inhibitory concentration: 15500 nM
Estimate against measurement, compound 4: 1.3-fold (0.11 log units) below; the range from low to high includes it.
By their numbers in this assay, from the lowest: compounds 3, 4, 1 and 2 (each within the scatter of the next, the first and the last beyond it).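

Compound 4 is the only one of the four with a hetero atom in the group on the carbonyl carbon, and in this assay it cannot be told apart from any of the other three (a 1.6-fold higher number from compound 3 to compound 4 (0.21 log units; within the scatter); a 1.6-fold lower number from compound 2 to compound 4 (0.20 log units; within the scatter); a 1.0-fold lower number from compound 1 to compound 4 (0.01 log units; within the scatter)). Replacing the six-membered carbon ring with a five-membered ring that holds an oxygen and a hydrogen-bond acceptor therefore leaves no readable mark on this number. Furan-2-yl also matches both ethyl and tert-butyl within the scatter, so at this position a ring is not set apart from an open-chain group.

As far as these compounds go, it remains open whether an amine or a carboxylic acid carried on this carbonyl carbon would leave this narrow band, and whether a thiophene ring would match furan-2-yl. Nothing measured here explains why these numbers fall as they do.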